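Trimming a Ring Nitrogen on a Shared Core

A few compounds are considered here, and "the series" means these few. Any claim that something is new, unique, unknown or untested is made for them only; others in the source may bear on it.

Compound 1 `CN1CCN(c2ccc(NC3=CC(=O)c4ncncc4C3=O)cc2)CC1`: 340 nM
Compound 2 `O=C1C(Nc2ccc(C3CCCCC3)cc2)=CC(=O)c2ncncc21`: 900 nM

Both were tested in a functional assay on PANC-1 cells (Homo sapiens) for cytotoxicity, read by MTT assay, with a stated time of 72 h; a lower number here means a stronger inhibitor, a higher number a weaker inhibitor. Within the data shown here, compound 1 gives the lowest of the two numbers; the one measured step is a 2.6-fold higher number from compound 1 to compound 2 (0.42 log units; beyond the scatter). Compound 3 `O=C1C(Nc2ccc(N3CCCCC3)cc2)=CC(=O)c2ncncc21` is not yet measured; it differs from compound 1 by piperidin-1-yl in place of 4-methylpiperazin-1-yl on an aromatic carbon. That earlier step bears on this one, since there too a nitrogen-containing ring gave way to a plainer ring, with a modest rise. The present change is smaller, so a smaller rise is expected, a 1.6-fold higher number from compound 1 to compound 3 (0.21 log units; within the scatter). For compound 3 in this assay the estimate is 550 nM, within 250 nM to 1200 nM.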

Compound 3, half-maximal inhibitory concentration: 1400 nM
Estimate against measurement, compound 3: 2.5-fold (0.41 log units) below, and the stated range ends below it.
By their numbers in this assay, from the lowest: compound 1; then compounds 2 and 3 (each within the scatter of the next).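

In this assay the ring stays six-membered, yet piperidin-1-yl in place of 4-methylpiperazin-1-yl gives a 4.1-fold higher number from compound 1 to compound 3 (0.61 log units; beyond the scatter) and so the outer ring nitrogen with its methyl counts at this position, not merely the presence of a ring. Replacing the remaining ring nitrogen of compound 3 with carbon gives the cyclohexyl of compound 2, and a 1.6-fold higher number from compound 2 to compound 3 (0.19 log units; within the scatter) shows no separation between them. No measurement here explains the loss. Still open, from the compounds shown here alone, is whether the nitrogen or its methyl matters, which an unsubstituted piperazin-1-yl or a morpholin-4-yl could help to separate.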